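Three carbamates at the assay limit, and a fourth

This account rests on a few compounds, and the source may have more. Where it says the series, first, only, none or still open, it means among the compounds named here.

Compound 1, `C#CCN1CCC(OC(=O)Nc2ccc(C(C)C)cc2)CC1`: in an assay on BTI-TN-5B1-4 cells for inhibition of Amine oxidase [flavin-containing] A (Homo sapiens), read by fluorescence and Amplex Red, using microsomes, with a stated time of 15 min (on this read-out higher numbers stand for weaker inhibition and lower numbers for stronger inhibition), compound 1 gives > 100000 nM, which is a limit of the assay and not a number.
Compound 2, `C#CCN1CCC(COC(=O)Nc2ccc(C(C)C)cc2)CC1`: in this assay compound 2 gives > 100000 nM, again a limit of the assay.
Compound 3, `CC(C)c1ccc(NC(=O)OC2CCN(Cc3ccccc3)CC2)cc1`: in this assay compound 3 gives > 100000 nM, once more a limit of the assay.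

Compound 1 and compound 3 differ in one place only: phenyl in place of ethynyl on a saturated chain carbon bound to an amine nitrogen in a ring. Since both readings are limits, the step that the two limits leave unreadable from compound 1 to compound 3 cannot be sized in either direction. All that can be said rests on (the limit of > 100000 nM in this assay, at which 3 of the 3 values shown sit).

Compound 2 is built on a different core from compound 1, and the difference between the two cores is not broken down here. Compound 4, `CC(C)c1ccc(NC(=O)OCC2CCN(Cc3ccccc3)CC2)cc1`, has not yet been measured in this assay. It differs from compound 2 by phenyl in place of ethynyl on a saturated chain carbon bound to an amine nitrogen in a ring, the same change, at the same place, that takes compound 1 to compound 3.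

The expectation for compound 4 therefore rests on one fact: every value shown so far sits at the limit of > 100000 nM in this assay, at which 3 of the 3 values shown sit, and the change in question did not move compound 1 off that limit when it became compound 3. The step of a number no higher from compound 2 to compound 4 (the limit leaves the size open) is accordingly expected to be essentially nil. Compound 4 is estimated at 100000 nM, within a span of 40000 nM to 300000 nM, and the assay is expected most likely to report only a limit for compound 4 as well.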

Compound 4, half-maximal inhibitory concentration: > 100000 nM
Compound 4: only a limit was reported; the forecaster's own chance of this, stated with the estimate: 85%; the middle value sits exactly at the limit.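

Among the compounds shown here, compound 4 and compound 2 both give only a limit of the assay, so no step between them can be read, in size or in direction. The same holds for every other pair here: the limit of > 100000 nM in this assay, at which 4 of the 4 values shown sit.

The compounds shown leave open how far past that limit each one lies, and whether in this assay propargyl and benzyl differ at all on either core.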